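The compounds below may be only part of what the source reports. "The series", "measured", "known", "first", "only" and "open" are said of these compounds alone.

The account concerns compounds built on the shared core of compound 1 `O=C(NCc1ccc(F)cc1)c1cccc(O)c1O` and follows one change made to it. In an ADME assay on NCI-H630 cells (Homo sapiens) for cytotoxicity, read by MTT assay, with a stated time of 72 h (a lower number here means that less compound is tolerated, a higher number that more compound is tolerated), compound 1 gives > 40000 nM, which is a limit of the assay and not a number. Compound 1 thus stands at the limit of > 40000 nM in this assay, at which 1 of the 2 values shown sits, so only a bound is known for it. Compound 2 `O=C(NCc1ccc(-c2cccs2)cc1)c1cccc(O)c1O` is the one measured companion; in this assay compound 2 gives 15000 nM. Within the data shown here, the step of an at least 2.6-fold lower number from compound 1 to compound 2 (0.42 log units; beyond the scatter) is the only measured step in the set. Compound 3 `CNC(=O)c1cc(F)ccc1CNC(=O)c1cccc(O)c1O` differs from compound 1 by methylcarbamoyl in place of hydrogen on an aromatic carbon. Among the measured compounds shown here, no measured step covers this change, since the step from compound 1 to compound 2 exchanges a different group; it shows only that a change on the same ring can bring the number out of the limit, and it bears on compound 3 merely in that loose sense. For compound 3 the expected step is a number no higher from compound 1 to compound 3 (the limit leaves the size open), with a fair chance that the assay again reports only a limit. Compound 3 is therefore estimated at 40000 nM in this assay, within 15000 nM to 100000 nM.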

Compound 3, half-maximal cytotoxic concentration: > 40000 nM
Compound 3 ended at the assay's limit (the forecaster's own chance of this, stated with the estimate: 55%); the middle value lies on the limit itself.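

Compound 3, like compound 1, stays at a limit of this assay and not at a number, so no step from compound 1 to compound 3 can be read: the limit of > 40000 nM in this assay, at which 2 of the 3 values shown sit.

The compounds shown leave open whether methylcarbamoyl in place of hydrogen on an aromatic carbon changes the tolerated concentration at all, and in which direction.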